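From Difluorophenyl to Trifluoromethyl on the Shared Core

This account rests on a few compounds, and the source may have more. Where it says the series, first, only, none or still open, it means among the compounds named here.

Three compounds measured in an ADME assay on the whole organism (Mus musculus, strain Swiss Webster) for pharmacokinetics, read by LC-MS, at a dose of 50 mg/kg by the oral route; a lower number here means less compound in the circulation, a higher number more compound in the circulation at the dose given:
- compound 1 `O=C(Nc1ccc(F)c(-c2nc3ncc(-c4cc(F)ccc4F)cc3[nH]2)c1)N1CCCC1`: 5620 ng.h/mL
- compound 2 `O=C(Nc1ccc(F)c(-c2nc3ncc(-c4ccc(F)cc4F)cc3[nH]2)c1)N1CCCC1`: 15600 ng.h/mL
- compound 3 `O=C(Nc1ccc(F)c(-c2nc3ncc(-c4cccc(F)c4F)cc3[nH]2)c1)N1CCCC1`: 4750 ng.h/mL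

Compound 3 gives 4750 ng.h/mL, level within the scatter with compound 1, as a 1.2-fold lower number from compound 1 to compound 3 (0.07 log units; within the scatter) shows. It sits well under compound 2, with a 3.3-fold lower number from compound 2 to compound 3 (0.52 log units; beyond the scatter). The change to compound 4 `O=C(Nc1ccc(F)c(-c2nc3ncc(C(F)(F)F)cc3[nH]2)c1)N1CCCC1` is trifluoromethyl in place of 2,3-difluorophenyl on an aromatic carbon.

Among the measured compounds shown here, the only measured steps that bear on this change rearrange the fluorines on the phenyl, and the largest are a 2.8-fold higher number from compound 1 to compound 2 (0.44 log units; beyond the scatter) and a 3.3-fold lower number from compound 2 to compound 3 (0.52 log units; beyond the scatter). For the measured compounds named here, none of them removes the ring, so the data offer no direct precedent and those steps serve only as a rough guide to how far this assay can move. The central expectation is a small upward move, with low confidence in its direction. The expected step is a 1.5-fold higher number from compound 3 to compound 4 (0.17 log units; within the scatter). The estimate for compound 4 is 7000 ng.h/mL, with an expected range of 1800 ng.h/mL to 25000 ng.h/mL.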

Compound 4, area under the concentration-time curve: 489 ng.h/mL
Estimate against measurement, compound 4: 14-fold (1.16 log units) above, outside the stated range (below it).
By their numbers in this assay, from the lowest: compound 4; then compounds 3 and 1 (each within the scatter of the next); then compound 2.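

In this assay, the fluorine pattern on the phenyl ring shifted the numbers only modestly, but the step to trifluoromethyl at this position is much bigger, whichever difluorophenyl it replaces (a 9.7-fold lower number from compound 3 to compound 4 (0.99 log units; beyond the scatter); an 11-fold lower number from compound 1 to compound 4 (1.06 log units; beyond the scatter); a 32-fold lower number from compound 2 to compound 4 (1.50 log units; beyond the scatter)). Compound 4 thus lies beyond the scatter of all three difluorophenyl compounds, and the step from the best of them is the largest shown, so this position tolerates far more change than the fluorine shifts alone suggested. No measurement given here accounts for the drop.

Since the aromatic ring leaves and trifluoromethyl enters in a single change, the two contributions cannot be separated. A methyl group or an unsubstituted phenyl on this carbon would help to tell them apart, and an amine there remains an open case.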